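Dichlorophenyl for hydroxyphenyl on an inactive anilide

The source may report more compounds than this note shows. Statements on the series, on what has been measured and on what is new or still open speak of the compounds shown alone.

The shared core of compound 1 `CC(C)Oc1ccc(NC(=O)CSc2nnc(Cc3nn(C)c(=O)c4ccccc34)n2C)cc1` carries an amide whose aryl group varies. In an assay on isolated protein (Mus musculus) for inhibition of IL15-IL15 receptor (Homo sapiens), read by resazurin assay, with stated times of 30 min and 2.5 days (on this read-out higher numbers stand for weaker inhibition and lower numbers for stronger inhibition), compound 1 gives > 30000 nM, which is a limit of the assay rather than a number. In this assay compound 2 `Cn1c(Cc2nn(C)c(=O)c3ccccc23)nnc1SCC(=O)Nc1ccc(O)cc1` gives "not active" (no number reported), so no number exists for it. Compound 3 `Cn1c(Cc2nn(C)c(=O)c3ccccc23)nnc1SCC(=O)Nc1ccc(Cl)cc1Cl` differs from compound 2 by 2,4-dichlorophenyl in place of 4-hydroxyphenyl on an amide-type nitrogen, with 2,4-dichlorophenyl in place of 4-hydroxyphenyl on an amide-type nitrogen. Among the measured compounds shown here, no measured pair shows this change, so no step beyond the scatter is expected in either direction. Compound 3 is expected to give 30000 nM, between 3000 nM and 100000 nM.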

Compound 3, half-maximal inhibitory concentration: 17300 nM
For compound 3 the middle estimate is 1.7-fold (0.24 log units) above the measured one; measured number inside the range.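

In this assay compound 3, with 2,4-dichlorophenyl on the amide-type nitrogen, gives 17300 nM, the only actual number among the three compounds shown. Replacing 4-isopropoxyphenyl with 2,4-dichlorophenyl gives an at least 1.7-fold lower number from compound 1 to compound 3 (0.23 log units; that floor lies within the scatter), so this change shows no firm gain, and the step involving the 4-hydroxyphenyl of compound 2 cannot be read. The comparison with compound 1 rests on a limit rather than a number: the limit of > 30000 nM in this assay, at which 1 of the 3 values shown sits.

Whether both chlorines are needed for a number to appear remains open, as 4-chlorophenyl is not among these compounds. As far as these compounds go, the effect of an amine or a carboxylic acid on this ring also remains open.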